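Swapping Nitrile for Trifluoromethyl on the Strongest Compound

A few compounds are considered here, and "the series" means these few. Any claim that something is new, unique, unknown or untested is made for them only; others in the source may bear on it.

So far, three compounds built on a shared core have been measured in a functional assay on HeLa cells (Homo sapiens) for cytotoxicity, read by CCK-8 assay, with a stated time of 24 h; a lower number here means a stronger inhibitor, a higher number a weaker inhibitor. Compound 1 `C/C(=C\c1cc(-c2ccc(F)cc2)co1)C(N)=O` gives 11800 nM, and compound 2 `C/C(=C\c1cccc(-c2ccccc2)c1)C(N)=O` gives 15700 nM. Compound 3 `C/C(=C\c1cc(-c2ccc(C#N)cc2)cs1)C(N)=O` stands well apart with 250 nM, the lowest of the three numbers and beyond the scatter of both others, so it is the strongest inhibitor measured so far. Compound 4 `C/C(=C\c1cc(-c2ccc(C(F)(F)F)cc2)cs1)C(N)=O` has not yet been tested; it differs from compound 3 in one place: trifluoromethyl in place of cyano on an aromatic carbon. Going by the values given here, no pair of measured compounds shows this exchange, so there is no measured step to lean on. The change is expected to shift potency only modestly, an estimated step of a 2.4-fold higher number from compound 3 to compound 4 (0.38 log units; beyond the scatter). Compound 4 is therefore expected to give about 600 nM, within a range from 150 nM to 2500 nM.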

Compound 4, half-maximal inhibitory concentration: > 50000 nM
Compound 4: no number, only a limit; the forecaster's own chance of this, stated with the estimate: 5%; middle value at least 83-fold (1.92 log units) away from the limit.
By their numbers in this assay, from the lowest: compound 3; then compounds 1 and 2 (each within the scatter of the next). At a limit, above all of these: compound 4.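

At this place on the six-membered aromatic ring, the group matters greatly: in this assay, trifluoromethyl in place of cyano gives an at least 200-fold higher number from compound 3 to compound 4 (2.30 log units; beyond the scatter). Going by these compounds, compound 4 reads only as a limit of the assay, so the true size of this step stays unknown: the limit of > 50000 nM in this assay, at which 1 of the 4 values shown sits. The low number of compound 3 therefore rests on the nitrile at this place, not on the shared core alone.

On these data alone, whether an amine, a carboxylic acid or a methoxy group here would keep that low number remains open. This single exchange also cannot say why the number moves so far.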